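Swapping a Ring-Bearing Group on an Amine Nitrogen

This account rests on a few compounds, and the source may have more. Where it says the series, first, only, none or still open, it means among the compounds named here.

In a functional assay on HeLa cells (Homo sapiens) for inhibition, read by MTT assay, with a stated time of 48 h (a lower number here means a stronger inhibitor, a higher number a weaker inhibitor), compound 1 (`CCOC(=O)C1=C(N/N=C(/C#N)C(=O)OCC)Nc2[nH]nc(C)c2C1c1ccc(N(C)C)cc1`) gives 39200 nM, and compound 2 (`CCOC(=O)C1=C(N/C=N/c2nnc(S(N)(=O)=O)s2)Nc2[nH]nc(C)c2C1c1ccc(N(C)C)cc1`) gives 26300 nM. Within the data shown here, these two values lie within the scatter of each other, so compound 2 stands level with the only other compound measured. Compound 3 (`CCOC(=O)C1=C(N/N=C(\C#N)C(N)=O)Nc2[nH]nc(C)c2C1c1ccc(N(C)C)cc1`) alters compound 2 in one place: a group of 7 heavy atoms (3 carbon, 3 nitrogen, 1 oxygen; no ring) in place of a group of 11 heavy atoms (3 carbon, 4 nitrogen, 2 oxygen, 2 sulfur; one five-membered aromatic ring with 3 hetero atoms), on an amine nitrogen. Among the measured compounds shown here, the one measured step that bears on this also exchanged a group with no ring and a group holding a five-membered aromatic ring, on an amine nitrogen. That step was small: a 1.5-fold lower number from compound 1 to compound 2 (0.17 log units; within the scatter). A single step is thin evidence, but it gives no reason to expect a shift beyond the scatter in this assay. The expected step is a 1.1-fold higher number from compound 2 to compound 3 (0.06 log units; within the scatter). For compound 3 the estimated value is 30000 nM, with an expected range of 12000 nM to 75000 nM.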

Compound 3, half-maximal inhibitory concentration: 47300 nM
Beside the measured number, compound 3's estimate is 1.6-fold (0.20 log units) below it; low and high end bracket the measured number.
By their numbers in this assay, from the lowest: compounds 2, 1 and 3 (each within the scatter of the next).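

In this assay the two new steps, a 1.8-fold higher number from compound 2 to compound 3 (0.25 log units; within the scatter) and a 1.2-fold higher number from compound 1 to compound 3 (0.08 log units; within the scatter), both stay within the scatter, so the three groups on this amine nitrogen now stand level with one another. Taking away the five-membered aromatic ring with 3 hetero atoms does not carry the number beyond the scatter, and neither does exchanging one ring-free group for a smaller one of 7 heavy atoms. Nothing available explains why these numbers stay level.

Going by these compounds, it remains open whether a plain amine, a carboxylic acid or a longer alkyl chain on this nitrogen would shift the number beyond the scatter. On these data alone, it is also open whether the same level picture would hold on a different core or in other cells.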